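Outer aryl exchange at the bile acid receptor

The compounds below may be only part of what the source reports. "The series", "measured", "known", "first", "only" and "open" are said of these compounds alone.

Among the measured compounds shown here, compound 2 `COC(=O)/C=C/c1cccc(N(Cc2ccc(-c3ccc(SC)cc3)cc2)C(=O)C(C)C)c1` gives 51 nM in an assay on isolated protein with Bile acid receptor (Homo sapiens) as the target (a lower number here means that less compound is needed, a higher number that more compound is needed for the effect), the lowest of the two numbers measured so far. Its nearest neighbour, compound 1 `COC(=O)/C=C/c1cccc(N(Cc2ccc(/C=C/c3cccc(F)c3)cc2)C(=O)C(C)C)c1`, gives 71 nM in this assay, and the step of a 1.4-fold lower number from compound 1 to compound 2 (0.14 log units; within the scatter) stays within the scatter. For the measured compounds named here, that single step is the only measured change at the outer aromatic group, and it shows the read-out unmoved by such an exchange.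

Compound 3 `CCOc1cccc(-c2ccc(CN(C(=O)C(C)C)c3cccc(/C=C/C(=O)OC)c3)cc2)c1` differs from compound 2 at the same place: 3-ethoxyphenyl in place of 4-(methylsulfanyl)phenyl on an aromatic carbon. Going by the values given here, no measured pair compares a 3-ethoxyphenyl with a 4-(methylsulfanyl)phenyl, so the only guide is the earlier exchange at this position, which remained within the scatter. A step of comparable size, without a clear direction, is therefore expected in this assay. For compound 3 the estimated step is a 1.2-fold higher number from compound 2 to compound 3 (0.07 log units; within the scatter). Compound 3 is expected to give 60 nM in this assay, with a plausible range from 25 nM to 150 nM given the limited evidence.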

Compound 3, half-maximal effective concentration: 173 nM
Beside the measured number, compound 3's estimate is 2.9-fold (0.46 log units) below it; measured number outside the range, above it.
By their numbers in this assay, from the lowest: compounds 2 and 1 (each within the scatter of the next); then compound 3.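

The outer aromatic group is not a place where every exchange leaves the read-out unmoved in (this assay): 3-ethoxyphenyl in place of 4-(methylsulfanyl)phenyl gives (a 3.4-fold higher number from compound 2 to compound 3 (0.53 log units; beyond the scatter)), and 3-ethoxyphenyl in place of 2-(3-fluorophenyl)ethenyl gives (a 2.4-fold higher number from compound 1 to compound 3 (0.39 log units; beyond the scatter)). Both steps lie beyond the scatter, whereas the two groups that leave in them remain within the scatter of each other, so compound 3 alone stands apart, although 3-ethoxyphenyl and 4-(methylsulfanyl)phenyl share one six-membered aromatic ring of carbon only, 0 hydrogen-bond donors and 1 hydrogen-bond acceptor. No supporting information bears on why this change moves the number.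

The compounds shown leave open whether the ethoxy group itself or its place on the outer ring goes with the higher number, as the step from 4-(methylsulfanyl)phenyl to 3-ethoxyphenyl alters both at once, a question that a 4-ethoxyphenyl group would separate. They also leave open how an outer ring carrying an amine or a carboxylic acid would read in (this assay).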